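The source may hold more compounds than are shown below. What is called first, only, known or untested is meant among the compounds shown, and "the series" means these compounds.

Measured so far:
compound 1, `C=CCOc1ccc2c(=O)c(-c3cc(OC)c(OC)cc3OC)coc2c1`: 5100 nM
compound 2, `COc1cc(OC)c(-c2coc3cc(OCC(=O)c4cccc(C(F)(F)F)c4)ccc3c2=O)cc1OC`: a limit, > 10000 nM
compound 3, `COc1cc(OC)c(-c2coc3cc(OCc4ccc(Br)cc4)ccc3c2=O)cc1OC`: 1180 nM

The three compounds share one core and differ only in the group carried on a saturated chain carbon bound to an oxygen on an aromatic ring. In a functional assay on B16 cells (Mus musculus) for antiproliferative activity, read by MTT assay, with a stated time of 24 h (on this read-out lower numbers stand for stronger inhibition and higher numbers for weaker inhibition), compound 1 gives 5100 nM, and compound 3 gives 1180 nM. For compound 2 this assay reports only a limit, > 10000 nM. Among the two numbers compound 1 stands highest; the nearest is compound 3, reached by a 4.3-fold lower number from compound 1 to compound 3 (0.64 log units; beyond the scatter). The move to the carbonyl-linked ring yields only a floor, an at least 1.9-fold higher number from compound 1 to compound 2 (0.29 log units; that floor lies within the scatter), while an at least 8.4-fold lower number from compound 2 to compound 3 (0.92 log units; beyond the scatter).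

Compound 4, `COc1cc(OC)c(-c2coc3cc(OCc4cccc(Br)c4)ccc3c2=O)cc1OC`, is now to be measured. Set against compound 1 the change is 3-bromophenyl in place of vinyl on a saturated chain carbon bound to an oxygen on an aromatic ring. Among the measured compounds shown here, the step that bears on it most directly is a 4.3-fold lower number from compound 1 to compound 3 (0.64 log units; beyond the scatter), where the same kind of bromine-bearing aromatic ring entered at the same place; the bromine now sits at a different position of that ring, for which no measured step exists. A step of similar size and in the same direction is expected, a 3.4-fold lower number from compound 1 to compound 4 (0.53 log units; beyond the scatter). Compound 4 is therefore estimated to give about 1500 nM in this assay, within a range from 500 nM to 5000 nM.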

Compound 4, half-maximal inhibitory concentration: 4400 nM
For compound 4 the middle estimate is 2.9-fold (0.47 log units) below the measured one; the range from low to high includes it.
By their numbers in this assay, from the lowest: compound 3; then compounds 4 and 1 (each within the scatter of the next). At a limit, above all of these: compound 2.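

The place of the bromine on the aromatic ring matters in this assay: 3-bromophenyl in place of 4-bromophenyl gives a 3.7-fold higher number from compound 3 to compound 4 (0.57 log units; beyond the scatter). A bromine-bearing aromatic ring at this place is therefore not enough on its own to lower the number, for 3-bromophenyl in place of vinyl gives only a 1.2-fold lower number from compound 1 to compound 4 (0.06 log units; within the scatter). Only a floor can be read against the carbonyl-linked ring, an at least 2.2-fold lower number from compound 2 to compound 4 (0.35 log units; beyond the scatter), and that step starts from a limit, not a number: the limit of > 10000 nM in this assay, at which 1 of the 4 values shown sits.

The compounds shown leave open whether the difference between 4-bromophenyl and 3-bromophenyl carries over when chlorine or a methoxy group takes the place of bromine. They also do not tell how an amine or a carboxylic acid on that aromatic ring, or a longer chain carrying the same ring, would read in this assay.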